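The compounds below may be only part of what the source reports. "The series", "measured", "known", "first", "only" and "open" are said of these compounds alone.

Working notes on the series. Three compounds share a core and differ in the group on a double-bonded chain carbon bound to an aromatic carbon and a double-bonded chain carbon. Compound 1 `O=C(O)CCCC/C=C(\c1cccnc1)c1cccc(Br)c1` carries 3-bromophenyl there, compound 2 `O=C(O)CCCC/C=C(\c1cccnc1)c1cccc(F)c1` carries 3-fluorophenyl, and compound 3 `O=C(O)CCCC/C=C(\c1cccnc1)c1ccsc1` carries thiophen-3-yl. In an assay (Equus caballus) for inhibition of Thromboxane-A synthase (Homo sapiens), using microsomes (on this read-out lower numbers stand for stronger inhibition and higher numbers for weaker inhibition), compound 1 gives 180 nM, compound 2 gives 55 nM and compound 3 gives 31 nM. Compound 3 stands at the lowest of the three numbers; its step from compound 1 is a 5.8-fold lower number from compound 1 to compound 3 (0.76 log units; beyond the scatter), beyond the scatter, while the step from compound 2 is a 1.8-fold lower number from compound 2 to compound 3 (0.25 log units; within the scatter) and stays within it. Replacing the halogen alone gave a 3.3-fold lower number from compound 1 to compound 2 (0.51 log units; beyond the scatter).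

Compound 4 `O=C(O)CCCC/C=C(/c1ccc(Br)cc1)c1cccnc1` is the next member, not yet measured in this assay. The change from compound 3 is 4-bromophenyl in place of thiophen-3-yl on a double-bonded chain carbon bound to an aromatic carbon and a double-bonded chain carbon: a six-membered ring of carbon only with one bromine enters where a five-membered ring with one sulfur leaves. Within the data shown here, the step that bears most directly is the reverse of the one from compound 1 to compound 3, since both place a bromophenyl group at the same chain carbon, though the bromine sits at a different ring position in compound 4 and no measured pair speaks to that. Given that reversal, a higher number than compound 3 is expected in this assay, of modest size, as a 3.5-fold higher number from compound 3 to compound 4 (0.55 log units; beyond the scatter). Compound 4 is therefore estimated at 110 nM, within a range of 35 nM to 350 nM.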

Compound 4, half-maximal inhibitory concentration: 82 nM
Compound 4: middle estimate off by 1.3-fold (0.13 log units), on the high side; the range from low to high includes it.
By their numbers in this assay, from the lowest: compounds 3, 2 and 4 (each within the scatter of the next, the first and the last beyond it); then compound 1.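

In this assay, among these compounds, the step of a 2.2-fold lower number from compound 1 to compound 4 (0.34 log units; beyond the scatter) is the first read on where the bromine sits: with 4-bromophenyl in place of 3-bromophenyl at the same chain carbon, the change lies beyond the scatter, so the halogen's ring position counts at this place and not only its identity. A bromophenyl group is also not necessarily the poor choice that compound 1 alone suggested, as a 1.5-fold higher number from compound 2 to compound 4 (0.17 log units; within the scatter) stays within the scatter and leaves 4-bromophenyl and 3-fluorophenyl indistinguishable here. Thiophen-3-yl still holds a real margin over 4-bromophenyl, with a 2.6-fold higher number from compound 3 to compound 4 (0.42 log units; beyond the scatter) lying beyond the scatter, although the series offers no explanation for any of these steps.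

As far as these compounds go, one pair of bromine isomers is all that speaks to ring position, so it remains open whether 4-fluorophenyl would differ from 3-fluorophenyl in the same direction. Also open, from the compounds shown here alone, are how unsubstituted phenyl, 4-methoxyphenyl or thiophen-2-yl would stand at this chain carbon, and whether a shorter chain carrying the carboxylic acid would alter these steps.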